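Aryl substituent exchange on the shared core

The compounds below may be only part of what the source reports. "The series", "measured", "known", "first", "only" and "open" are said of these compounds alone.

Measured compounds:
compound 1, `COc1ccc(C2=Nn3c(nnc3C(C)c3ccc4cc(OC)ccc4c3)SC2)cc1`: in a functional assay on MCF7 cells (Homo sapiens) for inhibition, read by sulforhodamine B assay, with a stated time of 72 h (a lower number here means a stronger inhibitor, a higher number a weaker inhibitor), compound 1 gives 6600 nM
compound 2, `COc1ccc2cc(C(C)c3nnc4n3N=C(c3ccc(C(F)(F)F)cc3)CS4)ccc2c1`: in this assay compound 2 gives 6900 nM

Compound 2 and compound 1 sit within the scatter of each other; the step is a 1.0-fold higher number from compound 1 to compound 2 (0.02 log units; within the scatter), so the two numbers cannot be ordered with confidence.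

Compound 3, `COc1ccc2cc(C(C)c3nnc4n3N=C(c3ccc(C)cc3)CS4)ccc2c1`, differs from compound 2 by methyl in place of trifluoromethyl on an aromatic carbon. Among the compounds with values here, the only measured step on this series concerns the same position: a 1.0-fold higher number from compound 1 to compound 2 (0.02 log units; within the scatter), a change of the substituent on that phenyl ring that left the number unchanged within the scatter. Within the data shown here, no measured step involves a methyl at this position, so the expectation rests on that single comparison. The step from compound 2 to compound 3 is therefore expected to fall within the scatter, a 1.1-fold lower number from compound 2 to compound 3 (0.03 log units; within the scatter). For compound 3 the estimated value in this assay is 6500 nM, with a range from 3000 nM to 14000 nM.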

Compound 3, half-maximal inhibitory concentration: 11000 nM
Estimate against measurement, compound 3: 1.7-fold (0.23 log units) below, and the stated range covers the measured number.
By their numbers in this assay, from the lowest: compounds 1, 2 and 3 (each within the scatter of the next).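

Methyl is a third group on this phenyl ring in this assay and it does not separate from the other two: a 1.6-fold higher number from compound 2 to compound 3 (0.20 log units; within the scatter) and a 1.7-fold higher number from compound 1 to compound 3 (0.22 log units; within the scatter) both stand within the scatter. Trifluoromethyl, methoxy and methyl at this position therefore cannot be ordered, and the exchange of 4-(trifluoromethyl)phenyl for 4-methylphenyl gives no readable effect on the number. No measured property bears on these steps, so nothing explains why the numbers stay together.

From the compounds shown here alone, whether an amine, a carboxylic acid or a longer chain such as butyl on this phenyl ring would take the number in this assay beyond the scatter remains open. The compounds shown all keep the rest of the shared core unchanged, so the part played by other positions stays unread.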